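The compounds below may be only part of what the source reports. "The series", "measured", "known", "first", "only" and "open" are said of these compounds alone.

Measured so far:
compound 1 `NC(=O)c1nn([C@@H]2O[C@H](CO)[C@@H](O)[C@H]2O)cc1I`, > 300000 nM
compound 2 `COC(=O)c1nn([C@@H]2O[C@H](CO)[C@@H](O)[C@H]2O)cc1I`, 2800 nM
compound 3 `O=C(O)c1nn([C@@H]2O[C@H](CO)[C@@H](O)[C@H]2O)cc1I`, > 300000 nM

Compound 1 gives only a limit, > 300000 nM, in a functional assay on HT-29 cells (Homo sapiens); a higher number here means a weaker inhibitor, a lower number a stronger inhibitor. Compound 3 likewise sits at a limit, > 300000 nM. Compound 2 alone has a number, 2800 nM in this assay. The two limits coincide, (the limit of > 300000 nM in this assay, at which 2 of the 3 values shown sit), so compound 1 stands at the upper edge of what this assay can report.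

Compound 4 `CCCCOC(=O)c1nn([C@@H]2O[C@H](CO)[C@@H](O)[C@H]2O)cc1I` differs from compound 1 by butoxy in place of amino on a carbonyl carbon. Among the measured compounds shown here, the one measured step that bears on this is an at least 100-fold lower number from compound 1 to compound 2 (2.02 log units; beyond the scatter), and the reverse reading, an at least 100-fold higher number from compound 2 to compound 3 (2.02 log units; beyond the scatter), points the same way. A large drop is therefore expected again: an estimated step of an at least 100-fold lower number from compound 1 to compound 4 (2.00 log units; beyond the scatter), giving compound 4 an expected value of about 3000 nM, between 600 nM and 20000 nM.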

Compound 4, half-maximal inhibitory concentration: 25000 nM
Compound 4: middle estimate off by 8.3-fold (0.92 log units), on the low side; the whole stated range lies below it.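

Butoxy on the carbonyl carbon also gives a readable value, with an at least 12-fold lower number from compound 1 to compound 4 (1.07 log units; beyond the scatter) and an at least 12-fold lower number from compound 3 to compound 4 (1.07 log units; beyond the scatter), so compound 2 is not the only ester to leave the limit. Both of these steps start from a limit of the assay: the limit of > 300000 nM in this assay, at which 2 of the 4 values shown sit. The ester group itself is not indifferent to chain length, since there is an 8.9-fold higher number from compound 2 to compound 4 (0.95 log units; beyond the scatter).

The compounds shown leave open how the value runs through an ethyl or propyl ester, and whether a chain longer than butyl raises it further. As far as these compounds go, a benzyl ester also remains open.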